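The source may hold more compounds than are shown below. What is called first, only, known or untested is meant among the compounds shown, and "the series" means these compounds.

Of the compounds shown here, three of a common scaffold have been measured in a functional assay on MGC-803 cells (Homo sapiens) for inhibition, read by MTT assay, with a stated time of 48 h; on this read-out higher numbers stand for weaker inhibition and lower numbers for stronger inhibition. Compound 1 `C/C=C/C(=O)N(Cc1ccc(OC)c([N+](=O)[O-])c1)c1cc(OC)c(OC)c(OC)c1` carries a crotonyl group on the amide nitrogen and a nitro group on its benzyl ring; in this assay compound 1 gives 590 nM. Compound 2 `COCC(=O)N(Cc1ccc(OC)c(O)c1)c1cc(OC)c(OC)c(OC)c1` instead carries a methoxymethyl carbonyl and a hydroxyl group in place of the nitro group; in this assay compound 2 gives 79 nM. Compound 3 `COc1ccc(N(Cc2cc(OC)c(OC)c(OC)c2)C(=O)CCl)cc1O` has the benzyl and aryl portions exchanged and a chloroacetyl group on the nitrogen; in this assay compound 3 gives 24500 nM.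

Compound 2 stands lowest of the three numbers, well beyond the scatter from compound 1 and far beyond it from compound 3. Compound 4 `COc1ccc(CN(C(=O)C(C)C)c2cc(OC)c(OC)c(OC)c2)cc1O` has not been measured. It differs from compound 2 in one place: isopropyl in place of methoxymethyl on a carbonyl carbon.

Among the compounds with values here, no measured pair in this set differs only at the acyl group, so no direct precedent for this change is available. The author expects the step from compound 2 to compound 4 to be small, most likely within the scatter, with a slight lean toward weaker inhibition, amounting to a 1.5-fold higher number from compound 2 to compound 4 (0.18 log units; within the scatter). Compound 4 is therefore estimated at 120 nM, with a range from 40 nM to 400 nM.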

Compound 4, half-maximal inhibitory concentration: 210 nM
Estimate against measurement, compound 4: 1.8-fold (0.24 log units) below; the range from low to high includes it.
By their numbers in this assay, from the lowest: compound 2; then compound 4; then compound 1; then compound 3.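

In this assay, isopropyl in place of methoxymethyl on a carbonyl carbon gives a 2.7-fold higher number from compound 2 to compound 4 (0.42 log units; beyond the scatter), a modest step that lies beyond the scatter. Within the data shown here, this is the only pair in the set that differs solely at the acyl group, and it shows that this place, on a carbonyl carbon whose other neighbour is the amide-type nitrogen, responds to the change even though the group that leaves and the group that enters both hold 3 heavy atoms and no ring: methoxymethyl has 2 carbon and 1 oxygen with 1 hydrogen-bond acceptor, whereas isopropyl has 3 carbon and 0 hydrogen-bond acceptors. Nothing available ties the step to the oxygen, to the branching, or to any other feature of the exchange.

A single pair cannot separate those features, and an ethoxymethyl, a methoxyethyl or a dimethylaminomethyl group at the same place would be needed to show how far the trend runs. The crotonyl and chloroacetyl groups of compound 1 and compound 3 also stay unresolved, since those compounds differ from compound 2 in more than one place.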